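Changing the aryl group of compound 2: an estimate for compound 4

The source may hold more compounds than are shown below. What is called first, only, known or untested is meant among the compounds shown, and "the series" means these compounds.

Of the compounds shown here, three have been measured in an assay for inhibition of Indoleamine 2,3-dioxygenase 1 (Homo sapiens), read by fluorescence, with a stated time of 24 h; a higher number here means a weaker inhibitor, a lower number a stronger inhibitor. Compound 2 `NS(=O)(=O)CC(=O)NCCSc1nonc1/C(=N/O)Nc1cccc(Cl)c1` gives 10 nM, the lowest number of the three. Compound 1 `NS(=O)(=O)CC(=O)NCCSc1nonc1/C(=N/O)Nc1cccc(C(F)F)c1` gives 17 nM, and the step of a 1.7-fold lower number from compound 1 to compound 2 (0.23 log units; within the scatter) lies within the scatter, so the two cannot be ordered. Compound 3 `COc1nonc1/C(=N/O)Nc1ccc(F)c(Br)c1`, which carries a different group on the shared core, gives 39 nM, a number beyond the scatter from that of compound 2.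

Compound 4 `NS(=O)(=O)CC(=O)NCCSc1nonc1/C(=N/O)Nc1ccc(F)c(Br)c1` has not been measured. It differs from compound 2 by 3-bromo-4-fluorophenyl in place of 3-chlorophenyl on an amine nitrogen. Among the compounds with values here, the only measured step that bears on this change is the one from compound 1 to compound 2, which also exchanges one substituent on the same aryl group and stays within the scatter. Within the data shown here, compound 3 shares the 3-bromo-4-fluorophenyl group of compound 4 but differs elsewhere, so its value offers no step for this change. The expectation is therefore a step of a 1.4-fold higher number from compound 2 to compound 4 (0.15 log units; within the scatter) that stays within the scatter. In this assay compound 4 is estimated at 14 nM, with a range from 5 nM to 40 nM.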

Compound 4, half-maximal inhibitory concentration: 12 nM
Compound 4: the middle estimate sits 1.2-fold (0.07 log units) above what was measured; the range from low to high includes it.
By their numbers in this assay, from the lowest: compounds 2, 4 and 1 (each within the scatter of the next); then compound 3.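

In this assay, the exchange on the amine nitrogen gives a 1.2-fold higher number from compound 2 to compound 4 (0.08 log units; within the scatter) and a 1.4-fold lower number from compound 1 to compound 4 (0.15 log units; within the scatter) as the two new steps, and both lie within the scatter. The position therefore now holds three aryl groups, with one substituent or with two, and compound 1, compound 2 and compound 4 cannot be ordered among themselves. Within the data shown here, the earlier compounds showed only one single-substituent exchange on this ring, whereas the 3-bromo-4-fluorophenyl group of compound 4 shows that a second halogen and one more heavy atom can enter with no step beyond the scatter. Nothing among the data shown explains why these groups give such close numbers.

On these data alone, all three aryl groups carry only halogen or difluoromethyl substituents, so it remains open whether an amine or a carboxylic acid on the ring, or a plain unsubstituted phenyl, would also stay within the scatter. As far as these compounds go, it also remains open whether 3-chlorophenyl and 3-bromo-4-fluorophenyl would stay this close on the methoxy-bearing core of compound 3.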